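This account rests on a few compounds, and the source may have more. Where it says the series, first, only, none or still open, it means among the compounds named here.

In an ADME assay on HEK293 cells (Homo sapiens) for cytotoxicity, read by MTT assay, with a stated time of 24 h (a higher number here means a weaker inhibitor, a lower number a stronger inhibitor), compound 1 `COc1ccc(/C=C/C(=O)c2c(C)cc(O)c(C(=O)/C=C/c3ccc(OC)cc3)c2-c2ccccc2)cc1` gives "not active" (no number reported), so no single number places it on the scale. Two related compounds do carry numbers: compound 2 `Cc1cc(O)c(C(=O)/C=C/c2ccc(F)cc2)c(-c2ccc(Br)cc2)c1C(=O)/C=C/c1ccc(F)cc1` gives 20000 nM in this assay, and compound 3 `Cc1cc(O)c(C(=O)/C=C/c2ccc(OCc3ccccc3)cc2)c(-c2ccc(OCc3ccccc3)cc2)c1C(=O)/C=C/c1ccc(OCc2ccccc2)cc1` gives 30000 nM; both values show only weak cytotoxicity. Compound 4 `COc1ccc(/C=C/C(=O)c2c(C)cc(O)c(C(=O)/C=C/c3ccc(OC)cc3)c2-c2ccc(OCc3ccccc3)cc2)cc1` differs from compound 1 by benzyloxy in place of hydrogen on an aromatic carbon, placed para to a large group. Because compound 3 with 30000 nM already bears benzyloxy groups and remains weak, no step beyond the usual scatter is expected here, and this assay may again report no number at all. Compound 4 is therefore estimated to show weak cytotoxicity, around 35000 nM, with a likely range from 15000 nM to 100000 nM.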

Compound 4, half-maximal inhibitory concentration: 28000 nM
Estimate against measurement, compound 4: 1.3-fold (0.10 log units) above, within the range that was stated.
By their numbers in this assay, from the lowest: compounds 2, 4 and 3 (each within the scatter of the next).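

In this assay compound 1 gives "not active" (no number reported) and compound 4 gives 28000 nM so no step can be read between these two compounds. Going by these compounds, whether benzyloxy in place of hydrogen changes the cytotoxicity stays open, and no further evidence bears on this result.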